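This account rests on a few compounds, and the source may have more. Where it says the series, first, only, none or still open, it means among the compounds named here.

Measured in a functional assay on MGC-803 cells (Homo sapiens) for inhibition, read by MTT assay, with a stated time of 72 h; on this read-out lower numbers stand for stronger inhibition and higher numbers for weaker inhibition:
- compound 1 `Cc1cc(N2CC[C@@H](C)[C@@H](N(C)c3ncnc4[nH]ccc34)C2)n2nc(SCc3csc4ccc(Cl)cc34)nc2n1` gives > 100000 nM (a limit of the assay)
- compound 2 `Cc1cc(N2CC[C@@H](C)[C@@H](N(C)c3ncnc4[nH]ccc34)C2)n2nc(SCc3ccc(F)cc3)nc2n1` gives 11900 nM
- compound 3 `Cc1cc(N2CC[C@@H](C)[C@@H](N(C)c3ncnc4[nH]ccc34)C2)n2nc(SCC3CCCCC3)nc2n1` gives 9170 nM
- compound 4 `Cc1ccc(CSc2nc3nc(C)cc(N4CC[C@@H](C)[C@@H](N(C)c5ncnc6[nH]ccc56)C4)n3n2)cc1` has not yet been measured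

The entry for compound 1 is a limit and not a number. Compound 3 stands level with compound 2 , with a 1.3-fold lower number from compound 2 to compound 3 (0.11 log units; within the scatter), and well clear of compound 1 , with an at least 10-fold lower number from compound 1 to compound 3 (1.03 log units; beyond the scatter).

Compound 4 differs from compound 3 by one exchange, (4-methylphenyl in place of cyclohexyl on a saturated chain carbon bound to a sulfur), with 4-methylphenyl in place of cyclohexyl on a saturated chain carbon bound to a sulfur. The closest measured precedent is compound 2 , which carries 4-fluorophenyl at that place. Within the data shown here, its exchange with cyclohexyl gave a 1.3-fold lower number from compound 2 to compound 3 (0.11 log units; within the scatter), so the one measured swap between these two kinds of ring moved nothing beyond the scatter. The step of an at least 8.4-fold lower number from compound 1 to compound 2 (0.92 log units; beyond the scatter) is also sizeable, but it starts from the 5-chloro-1-benzothiophen-3-yl group of compound 1 and bears less directly on this change. No step beyond the scatter is therefore expected in this assay, in either direction. The estimate corresponds to an expected 1.2-fold higher number from compound 3 to compound 4 (0.08 log units; within the scatter). Compound 4 is expected at 11000 nM, with an estimated range of 5000 nM to 30000 nM.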

Compound 4, half-maximal inhibitory concentration: 5860 nM
Estimate against measurement, compound 4: 1.9-fold (0.27 log units) above; measured number inside the range.
By their numbers in this assay, from the lowest: compounds 4, 3 and 2 (each within the scatter of the next, the first and the last beyond it). At a limit, above all of these: compound 1.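

In this assay, 4-methylphenyl in place of cyclohexyl on a saturated chain carbon bound to a sulfur gives a 1.6-fold lower number from compound 3 to compound 4 (0.19 log units; within the scatter), so a second substituted aromatic ring also stands level with the cyclohexyl group at this place. Among these compounds, what is new is a change on the ring itself: methyl in place of fluoro on an aromatic carbon gives a 2.0-fold lower number from compound 2 to compound 4 (0.31 log units; beyond the scatter), the first step beyond the scatter among the compounds with a single six-membered ring here, though only a modest one. Exchanging 5-chloro-1-benzothiophen-3-yl for 4-methylphenyl gives an at least 17-fold lower number from compound 1 to compound 4 (1.23 log units; beyond the scatter), so this ring also stands well clear of that group, although the step rests on a limit of the assay and not on a number: the limit of > 100000 nM in this assay, at which 1 of the 4 values shown sits.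

The compounds shown leave open whether an amine or a carboxylic acid in place of the methyl on the aromatic ring would move the number further in either direction. They also leave open how a longer chain between the sulfur and the ring would read in this assay.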